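Phenethyl in place of 4-pentylphenyl

The source may hold more compounds than are shown below. What is called first, only, known or untested is meant among the compounds shown, and "the series" means these compounds.

Measured in a functional assay on HepG2 cells (Homo sapiens) for antiproliferative activity, read by MTT assay, with a stated time of 3 days; a higher number here means a weaker inhibitor, a lower number a stronger inhibitor:
Compound 1 `Cc1ccc(C#Cc2cn(C/C=C\CN3C(=O)c4ccccc4C3=O)c(=O)[nH]c2=O)cc1`: 68000 nM
Compound 2 `CCCCCc1ccc(C#Cc2cn(C/C=C\CN3C(=O)c4ccccc4C3=O)c(=O)[nH]c2=O)cc1`: 18000 nM

Of these two compounds, compound 2 has the lower number, 18000 nM. The next compound, compound 3 `O=C1c2ccccc2C(=O)N1C/C=C\Cn1cc(C#CCCc2ccccc2)c(=O)[nH]c1=O`, carries phenethyl in place of 4-pentylphenyl on a triple-bonded carbon of the shared core: phenethyl in place of 4-pentylphenyl on a triple-bonded carbon. For the measured compounds named here, only one measured step bears on this change. In this assay the step was a 3.8-fold lower number from compound 1 to compound 2 (0.58 log units; beyond the scatter), modest but beyond the scatter, with butyl in place of hydrogen on a saturated chain carbon bound to an aromatic carbon. Compound 3 loses the 4-pentylphenyl group, but the change is not a simple reversal of that step. A modest rise is therefore expected, not one much larger than the measured step. The expected step is a 2.2-fold higher number from compound 2 to compound 3 (0.35 log units; beyond the scatter). For compound 3 the estimated value is 40000 nM, with an expected range of 17000 nM to 100000 nM.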

Compound 3, half-maximal inhibitory concentration: > 100000 nM
Compound 3: only a limit was reported; the forecaster's own chance of this, stated with the estimate: 15%; at least 2.5-fold (0.39 log units) between middle value and limit.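

In this assay compound 3 stands only as a limit: the limit of > 100000 nM in this assay, at which 1 of the 3 values shown sits.

Phenethyl on the triple-bonded carbon gives an at least 5.5-fold higher number from compound 2 to compound 3 (0.74 log units; beyond the scatter), so carrying one six-membered aromatic ring of carbon only, as both groups do, is not enough to hold the number of compound 2 at this position. Set against 4-methylphenyl, the same kind of change gives an at least 1.4-fold higher number from compound 1 to compound 3 (0.16 log units; that floor lies within the scatter), so this limit does not firmly separate phenethyl from that smaller aryl group.

How far compound 3 truly lies from the other two remains unknown, and no cause for the loss can be read from three compounds. Also open, going by these compounds, is whether a plain hexyl chain, or a phenyl group carrying an amine or a carboxylic acid, would give a measurable value on the same triple-bonded carbon.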